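A Ring Swap on Compound 2 and Its Expected Effect

The compounds below may be only part of what the source reports. "The series", "measured", "known", "first", "only" and "open" are said of these compounds alone.

Measured compounds:
- compound 1 `Cc1cc(C)c(NC(=O)N(Cc2ccc(-c3n[nH]c(C)n3)cc2)C2CCCCCC2)c(C)c1`: 120 nM
- compound 2 `O=C(Nc1c(F)cc(F)cc1F)N(Cc1ccc(-c2ccsc2)cc1)C1CCCCCC1`: 23 nM
- compound 3 `Cc1cc(C)c(NC(=O)N(Cc2ccc(-c3ccsc3)cc2)C2CCCCCC2)c(C)c1`: 19 nM

In an assay on microsomes from intestine for inhibition of acyl-CoA:cholesterol acyltransferase (Oryctolagus cuniculus) (a higher number here means a weaker inhibitor, a lower number a stronger inhibitor), compound 2 sits second highest of the three numbers; its nearest neighbour is compound 3, with a 1.2-fold lower number from compound 2 to compound 3 (0.08 log units; within the scatter), while compound 1 lies furthest away, with a 6.3-fold lower number from compound 1 to compound 3 (0.80 log units; beyond the scatter) separating compound 1 from compound 3. Compound 4 `O=C(Nc1c(F)cc(F)cc1F)N(Cc1ccc(-c2ccccn2)cc1)C1CCCCCC1` carries pyridin-2-yl in place of thiophen-3-yl on an aromatic carbon. Going by the values given here, the only measured step that bears on this end of the molecule is from compound 1 to compound 3, where a thiophen-3-yl replaced a 5-methyl-1H-1,2,4-triazol-3-yl and the number fell, a 6.3-fold lower number from compound 1 to compound 3 (0.80 log units; beyond the scatter). Pyridin-2-yl is neither of those rings, so the direction is uncertain; a small rise in the number is expected, a 1.7-fold higher number from compound 2 to compound 4 (0.24 log units; within the scatter). Compound 4 is therefore estimated at 40 nM, between 15 nM and 120 nM.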

Compound 4, half-maximal inhibitory concentration: 25 nM
For compound 4 the middle estimate is 1.6-fold (0.20 log units) above the measured one; the measured number falls inside the stated range.
By their numbers in this assay, from the lowest: compounds 3, 2 and 4 (each within the scatter of the next); then compound 1.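

In this assay, the earlier step, a 6.3-fold lower number from compound 1 to compound 3 (0.80 log units; beyond the scatter), showed that the ring at this position can matter. The new step, a 1.1-fold higher number from compound 2 to compound 4 (0.04 log units; within the scatter), shows that a six-membered aromatic ring with nitrogen can stand in for a five-membered one with sulfur, with the result staying within the scatter. Nothing available explains this match.

Still open, from the compounds shown here alone, is whether a carboxylic acid or a saturated amine such as piperidine would fit here, and whether pyridin-2-yl would give the same result alongside 2,4,6-trimethylphenyl.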